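A few compounds are considered here, and "the series" means these few. Any claim that something is new, unique, unknown or untested is made for them only; others in the source may bear on it.

Measured compounds in an assay on membranes from HeLa cells for displacement of a labelled ligand from adenosine receptor A3 (Homo sapiens), read by scintillation counting, with a stated time of 180 min, tested at 1 uM; on this read-out lower numbers stand for less inhibition and higher numbers for more inhibition at the one concentration tested (going by the name of the read-out):
- compound 1, `CC1=C(C(=O)CC(C)C)C(c2ccco2)NC(=O)N1`: 31%
- compound 2, `CC1=C(C(=O)CC(C)C)C(c2cccs2)NC(=O)N1`: 18%
- compound 3, `CC(=O)C1=C(C)NC(=O)NC1c1ccsc1`: 1%

Compound 3 stands lowest of the three numbers in this assay. Its nearest neighbour is compound 2, whose number lies higher by a gap beyond the scatter, and compound 1 lies higher still. Within the data shown here, the only step measured between compounds that differ in a single place is the ring swap a number 13 percentage points lower from compound 1 to compound 2 (beyond the scatter), which concerns the ring on the saturated ring carbon and not the chain on the carbonyl.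

Compound 4, `CC1=C(C(=O)CC(C)C)C(c2ccsc2)NC(=O)N1`, has not yet been measured. It differs from compound 3 as follows: isopropyl in place of hydrogen on a saturated chain carbon bound to a carbonyl carbon. Among the measured compounds shown here, no measured step covers this change directly. What the numbers do show is that compound 1 and compound 2, both carrying the isobutylcarbonyl chain, give higher values than compound 3 with its acetyl group, although they also carry different rings. On that basis the expected step of a number 13 percentage points higher from compound 3 to compound 4 (beyond the scatter) is upward, with considerable uncertainty. Compound 4 is estimated to reach 14% in this assay, with a plausible range from 2% to 30%.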

Compound 4, a percentage reported as inhibition, at one concentration (the size of the read-out at that concentration, not a potency): 14%
Beside the measured number, compound 4's estimate shows no gap at the digits printed, and the stated range covers the measured number.
By their numbers in this assay, from the lowest: compound 3; then compounds 4 and 2 (each within the scatter of the next); then compound 1.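

In this assay the chain on the carbonyl can now be read on its own: with thiophen-3-yl held constant, isobutylcarbonyl in place of acetyl gives a number 13 percentage points higher from compound 3 to compound 4 (beyond the scatter) and so accounts for a modest rise that compounds 1, 2 and 3 could not separate from their differences in the ring. On the saturated ring carbon, changing the point of attachment of the thiophene gives a number 4 percentage points lower from compound 2 to compound 4 (within the scatter) and so leaves no readable difference between thiophen-2-yl and thiophen-3-yl at this position. Thiophen-3-yl in place of furan-2-yl gives a number 17 percentage points lower from compound 1 to compound 4 (beyond the scatter) and matches the drop already seen with thiophen-2-yl, which leaves furan-2-yl above both thiophene rings, though nothing available here explains the size of any of these steps.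

From the compounds shown here alone, whether the rise from the longer chain also holds with furan-2-yl on the ring remains open. So does the effect on this read-out of other groups on the carbonyl, such as an ethyl chain, a longer hexyl chain or a chain ending in an amine.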